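The compounds below may be only part of what the source reports. "The series", "measured", "known", "first", "only" and "open" are said of these compounds alone.

Measured so far in a functional assay on MCF7 cells (Homo sapiens) for inhibition, read by MTT assay, with a stated time of 48 h; a lower number here means a stronger inhibitor, a higher number a weaker inhibitor:
- compound 3, `O=C(CSc1nnc(-c2ccncc2)n1-c1ccccc1)N/N=C/c1ccc(Br)cc1`: 7040 nM
- compound 1, `Clc1ccccc1CSc1nnc(-c2ccncc2)n1-c1ccccc1`: 18100 nM
- compound 2, `c1ccc(CSc2nnc(-c3ccncc3)n2-c2ccccc2)cc1`: 22400 nM

Compound 3 stands lowest of the three numbers. Compound 1 gives 18100 nM and compound 2 gives 22400 nM, and both of those gaps to compound 3 lie beyond the usual scatter, so compound 3 is the strongest inhibitor among the measured set. Compound 4, `O=C(CSc1nnc(-c2ccncc2)n1-c1ccccc1)N/N=C/c1cc(Br)cc(Br)c1O`, keeps the whole of compound 3 apart from one change: 3,5-dibromo-2-hydroxyphenyl in place of 4-bromophenyl on a carbon with a double bond to nitrogen.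

Among the measured compounds shown here, only one measured step exists, a 1.2-fold higher number from compound 1 to compound 2 (0.09 log units; within the scatter), and it concerns a halogen on a different part of the shared core, far from the carbon with a double bond to nitrogen. That step stayed within the scatter, which is weak guidance: it hints that swapping halogens on an outer ring does little, but nothing measured speaks to adding a hydroxyl or a second bromine on the ring that enters here. With so thin a basis, the expected step is none beyond the scatter, and the estimate is a 1.1-fold lower number from compound 3 to compound 4 (0.03 log units; within the scatter) with a wide band around it. Compound 4 is therefore estimated at 6500 nM, expected to fall between 2000 nM and 20000 nM.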

Compound 4, half-maximal inhibitory concentration: 8440 nM
Beside the measured number, compound 4's estimate is 1.3-fold (0.11 log units) below it; low and high end bracket the measured number.
By their numbers in this assay, from the lowest: compounds 3 and 4 (each within the scatter of the next); then compounds 1 and 2 (each within the scatter of the next).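

Among the compounds shown here, at the carbon with a double bond to nitrogen, the earlier compounds gave no information, and this pair gives the first: in this assay, 3,5-dibromo-2-hydroxyphenyl in place of 4-bromophenyl gives a 1.2-fold higher number from compound 3 to compound 4 (0.08 log units; within the scatter). The two compounds therefore cannot be told apart in this assay, even though the entering group has 9 heavy atoms where the leaving group has 7, and 1 hydrogen-bond donor and 1 hydrogen-bond acceptor where the leaving group has 0, so at this position and in this pair these differences in the ring come with no readable shift in the number. Nothing available explains this result.

On these data alone, the hydroxyl and the bromine atoms differ together in this single step, so what each does alone remains open, and a pair in which only one of them differs would be needed to separate them. As far as these compounds go, it also remains open how this assay would respond at this carbon to a ring bearing an amine or a carboxylic acid, or to a longer carbon chain in place of the ring.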